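Replacing cyanomethyl with 4-ethoxyphenyl on an amide nitrogen

A few compounds are considered here, and "the series" means these few. Any claim that something is new, unique, unknown or untested is made for them only; others in the source may bear on it.

Measured in a functional assay on PC-3 cells (Homo sapiens) for antiproliferative activity, read by MTT assay, with a stated time of 48 h; a lower number here means a stronger inhibitor, a higher number a weaker inhibitor:
Compound 1 `CCn1c(C(=O)NCCN(C)C)ccc1C(CC)(CC)c1ccc(OCCC(O)(CC)CC)c(C)c1`: 870 nM
Compound 2 `CCn1c(C(=O)NCC#N)ccc1C(CC)(CC)c1ccc(OCCC(O)(CC)CC)c(C)c1`: 17800 nM
Compound 3 `C#CCCOC(=O)c1ccc(C(CC)(CC)c2ccc(OCCC(O)(CC)CC)c(C)c2)n1CC`: > 50000 nM, a limit of the assay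

Of the two actual numbers, the higher belongs to compound 2 at 17800 nM. Compound 4 `CCOc1ccc(NC(=O)c2ccc(C(CC)(CC)c3ccc(OCCC(O)(CC)CC)c(C)c3)n2CC)cc1` differs from it as follows: 4-ethoxyphenyl in place of cyanomethyl on an amide-type nitrogen. For the measured compounds named here, no measured step makes this exchange. The closest steps change the same amide substituent or the amide itself: a 20-fold higher number from compound 1 to compound 2 (1.31 log units; beyond the scatter), which is large, and an at least 2.8-fold higher number from compound 2 to compound 3 (0.44 log units; beyond the scatter), which is at least modest. Neither gives a direction for 4-ethoxyphenyl, so no step beyond the scatter is expected in this assay. The expected step is a 1.1-fold higher number from compound 2 to compound 4 (0.05 log units; within the scatter). The estimate for compound 4 is 20000 nM, with an expected range of 6000 nM to 50000 nM.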

Compound 4, half-maximal inhibitory concentration: > 50000 nM
Compound 4: only a limit was reported; the forecaster's own chance of this, stated with the estimate: 25%; at least 2.5-fold (0.39 log units) between middle value and limit.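

In this assay, a six-membered aromatic ring on the amide nitrogen does not restore activity: the change gives an at least 2.8-fold higher number from compound 2 to compound 4 (0.44 log units; beyond the scatter), and against the 2-(dimethylamino)ethyl amide it gives an at least 57-fold higher number from compound 1 to compound 4 (1.75 log units; beyond the scatter). Compound 1 thus keeps the lowest number among these four compounds, and a large aryl group joins cyanomethyl on the weak side. Compound 4 and compound 3 both end at the assay limit, so the step between them cannot be read: the limit of > 50000 nM in this assay, at which 2 of the 4 values shown sit.

From the compounds shown here alone, whether a plain phenyl group on this nitrogen behaves like 4-ethoxyphenyl remains open. So does whether a longer chain ending in a dimethylamino group or a carboxylic acid would move the number.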